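Enantiomer of compound 2 at the adenosine A3 receptor

A few compounds are considered here, and "the series" means these few. Any claim that something is new, unique, unknown or untested is made for them only; others in the source may bear on it.

Of the compounds shown here, two have been measured in an assay on membranes from HeLa cells for displacement of a labelled ligand from adenosine receptor A3 (Homo sapiens), read by scintillation counting, with a stated time of 180 min, tested at 1 uM; a lower number here means less inhibition, a higher number more inhibition at the concentration tested (going by the name of the read-out). Compound 1 `CC1=C(C(=O)OCC(C)C)C(c2cccs2)NC(=O)N1` gives 11% in this assay. Compound 2 `CC1=C(C(=O)OC(C)C)[C@H](c2ccco2)NC(=S)N1` gives 2% in this assay, and the value of compound 1 lies within the usual scatter of it, so the two cannot be ordered. Compound 3 `CC1=C(C(=O)OC(C)C)[C@@H](c2ccco2)NC(=S)N1` is the enantiomer: the two compounds have the same atoms and bonds and differ only in configuration as drawn: 1 of 1 stereo elements differ; a stereocentre at a saturated ring carbon is drawn R in compound 2 and S in compound 3. Among the compounds with values here, no step between measured compounds is available, and a change of configuration alone gives no ground here to expect a shift beyond the scatter in this assay. Compound 3 is therefore expected to give 5% (range -8% to 20%), a step of a number 3 percentage points higher from compound 2 to compound 3 (within the scatter) that is expected to stay within the scatter.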

Compound 3, a percentage reported as inhibition, at one concentration (the size of the read-out at that concentration, not a potency): 1%
For compound 3 the middle estimate is 4 percentage points above the measured one; the measured number falls inside the stated range.
By their numbers in this assay, from the lowest: compounds 3, 2 and 1 (each within the scatter of the next).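

The change from R to S at the stereocentre on the saturated ring carbon comes out as a number 1 percentage points lower from compound 2 to compound 3 (within the scatter) in this assay. Within the data shown here, this is the first comparison of compounds that differ in one place, and it shows no effect of configuration at this carbon beyond the scatter at the concentration tested. Any difference in this pair could have only one structural source: the fact that compounds 2 and 3 differ only in the configuration as drawn

Going by these compounds, whether configuration matters in a compound that gives clear inhibition remains open. So does the effect of a carboxylic acid or a longer chain on the shared core.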